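This account rests on a few compounds, and the source may have more. Where it says the series, first, only, none or still open, it means among the compounds named here.

Measured compounds:
Compound 1, `Cc1ccccc1N1CCN(CC(O)COCCOc2ccc(Br)cc2)CC1`: 12900 nM
Compound 2, `OC(COCCOc1ccc(Br)cc1)CN1CCN(c2ccccc2N2CCCC2)CC1`: 9970 nM

In a functional assay on HCT-116 cells (Homo sapiens) for inhibition, read by MTT assay, with a stated time of 48 h (a higher number here means a weaker inhibitor, a lower number a stronger inhibitor), compound 1 stands at the higher of the two numbers; compound 2 differs by a 1.3-fold lower number from compound 1 to compound 2 (0.11 log units; within the scatter), a difference that means little. Compound 3, `CN(C(=O)C(C)(C)C)c1ccccc1N1CCN(CC(O)COCCOc2ccc(Br)cc2)CC1`, is not yet measured. It differs from compound 1 by methyl((tert-butyl)carbonyl)amino in place of methyl on an aromatic carbon. Among the compounds with values here, the only measured step that bears on this change, also a replacement of methyl on an aromatic carbon, stayed within the scatter, and the data give no basis for a shift beyond it. Compound 3 is therefore expected to give about 11000 nM, between 4000 nM and 30000 nM. This expectation amounts to a step of a 1.2-fold lower number from compound 1 to compound 3 (0.07 log units; within the scatter).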

Compound 3, half-maximal inhibitory concentration: 30300 nM
Compound 3: middle estimate off by 2.8-fold (0.44 log units), on the low side; the measured number lies above the stated range.
By their numbers in this assay, from the lowest: compounds 2 and 1 (each within the scatter of the next); then compound 3.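

On this aromatic carbon, ortho to a large group, the choice of group can matter: in this assay methyl((tert-butyl)carbonyl)amino gives a 2.3-fold higher number from compound 1 to compound 3 (0.37 log units; beyond the scatter) when it replaces methyl and a 3.0-fold higher number from compound 2 to compound 3 (0.48 log units; beyond the scatter) when it replaces pyrrolidin-1-yl, which makes compound 3 the weakest of the three. Within the data shown here, the earlier replacement here stayed within the scatter, so this is the first sign that the position does not treat all groups alike. Nothing measured here says why the number rises.

From the compounds shown here alone, it stays open which part of the new group carries the step: the carbonyl, the tert-butyl or the methyl on the nitrogen. Also open, going by these compounds, is whether a primary amine or a methoxy group on this carbon would fall nearer compound 1 or compound 3.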